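A few compounds are considered here, and "the series" means these few. Any claim that something is new, unique, unknown or untested is made for them only; others in the source may bear on it.

Among the compounds with values here, in an ADME assay on the whole organism (Rattus norvegicus, strain Sprague-Dawley), read by LC-MS, with stated times of 5 min and 24 h, at a dose of 5 mg/kg by the oral route (a lower number here means that the compound disappears faster, a higher number that the compound lasts longer), two compounds that share a core have numbers so far. Compound 1 `N#Cc1cnc(NC(=O)N2CCCc3cc(CN4CCOCC4=O)c(C=O)nc32)cc1S[C@H]1CCOC1` gives 3.5 h in this measurement, and compound 2 `COCCNc1cc(NC(=O)N2CCCc3cc(CN4CC[C@H](OC)C4=O)c(C=O)nc32)ncc1C#N` gives 2.9 h as its mean residence time. These two values lie within the usual scatter of each other, so compound 2 stands level with compound 1 on the evidence available.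

The next molecule is compound 3 `COCCNc1cc(NC(=O)N2CCCc3cc(CN4CC[C@@H](OC)C4=O)c(C=O)nc32)ncc1C#N`, and it is built from exactly the same parts as compound 2. The difference is this: the two compounds have the same atoms and bonds and differ only in configuration as drawn: 1 of 1 stereo elements differ; a stereocentre at a saturated ring carbon is drawn S in compound 2 and R in compound 3 and nothing else in the structure is altered. Within the data shown here, no pair of measured compounds shows what such a switch in configuration does to this assay and the data therefore give no direction for it. Among the measured compounds shown here, with no step to draw on, the best starting point is compound 2 at 2.9 h as the value of its closest relative.

The estimated 1.0-fold higher number from compound 2 to compound 3 (0.01 log units; within the scatter) stays within the scatter, with neither direction favoured. For compound 3 the expected value is 3 h with an estimated range from 1.7 h to 5 h for most repeat measurements.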

Compound 3, mean residence time: 3.2 h
Compound 3: middle estimate off by 1.1-fold (0.03 log units), on the low side; the range from low to high includes it.
By their numbers in this assay, from the lowest: compounds 2, 3 and 1 (each within the scatter of the next).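

In this assay, within the data shown here, switching the stereocentre at the saturated ring carbon from S to R gives a 1.1-fold higher number from compound 2 to compound 3 (0.04 log units; within the scatter), the first measured step for a switch in configuration in this set. Within the scatter, then, the two arrangements at this carbon stand level in how long the compound lasts in the rat, and neither configuration can be preferred on this read-out. The comparison is a clean one, and any effect it could have revealed would belong to this stereocentre alone, because of what sets the pair apart: the fact that compounds 2 and 3 differ only in the configuration as drawn.

This single pair cannot say whether configuration at this carbon would matter as little with a different structure elsewhere in the molecule, such as the group carried by compound 1 on the other ring. It also leaves open what would happen if the group on this carbon were replaced altogether, for example by a carboxylic acid or a fluorine atom, since both compounds here differ only in how their shared group is oriented.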